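Removing an amino group from a weak kinase inhibitor

The compounds below may be only part of what the source reports. "The series", "measured", "known", "first", "only" and "open" are said of these compounds alone.

Compound 1 `O=S(=O)(Nc1cc(-c2ccc3nc[nH]c3c2)cnc1Cl)c1ccc(F)cc1` gives > 12000 nM in an assay on U-87MG ATCC cells for inhibition of RAC-alpha serine/threonine-protein kinase (Homo sapiens), read by AlphaScreen, with a stated time of 2 h (a lower number here means a stronger inhibitor, a higher number a weaker inhibitor), which is a limit of the assay rather than a number. Compound 2 `O=S(=O)(Nc1cc(-c2ccc3sncc3c2)cnc1Cl)c1ccc(F)cc1` gives > 12000 nM, again a limit. Compound 3 `Nc1cn2cc(-c3cnc(Cl)c(NS(=O)(=O)c4ccc(F)cc4)c3)ccc2n1` gives > 12000 nM, also a limit.

Going by the values given here, compound 3 therefore stands at the limit of this assay, and the limit of > 12000 nM in this assay, at which 3 of the 3 values shown sit, shows that every measured value sits there, so no compound can be ranked against another. Compound 4 `O=S(=O)(Nc1cc(-c2ccc3nccn3c2)cnc1Cl)c1ccc(F)cc1` differs from compound 3 by hydrogen in place of amino on an aromatic carbon. Among the compounds with values here, the only measured step, a step that the two limits leave unreadable from compound 1 to compound 2, concerns a different part of the molecule and cannot be read. Within the data shown here, no step bears on the amino group, so the expectation is a step that the limit leaves unreadable from compound 3 to compound 4, no change beyond the scatter. Compound 4 is expected at 20000 nM, between 8000 nM and 60000 nM, most likely reported again as a limit.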

Compound 4, half-maximal inhibitory concentration: 574 nM
Compound 4: middle estimate off by 35-fold (1.54 log units), on the high side, outside the stated range (below it).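

Hydrogen in place of amino on this aromatic carbon gives an at least 20-fold lower number from compound 3 to compound 4 (1.32 log units; beyond the scatter), the first readable change at this position. The fused two-ring group as a whole also matters, as swapping it gives an at least 20-fold lower number from compound 2 to compound 4 (1.32 log units; beyond the scatter) and an at least 20-fold lower number from compound 1 to compound 4 (1.32 log units; beyond the scatter). Compound 4 is the only compound shown that leaves the limit of the assay: the limit of > 12000 nM in this assay, at which 3 of the 4 values shown sit.

From the compounds shown here alone, the true size of these steps stays open, since each starts from a limit. Also open, going by these compounds, is whether a methyl group or a fluorine atom on this carbon would behave like hydrogen or like amino.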